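The source may report more compounds than this note shows. Statements on the series, on what has been measured and on what is new or still open speak of the compounds shown alone.

Of the compounds shown here, three have been tested in a functional assay (aorta) for inhibition, with Rattus norvegicus as the target; a lower number here means that less compound is needed, a higher number that more compound is needed for the effect. Compound 1 `O=C1C(Nc2cccc(F)c2)=CC(=O)c2ncccc21` gives 805 nM. Compound 2 `O=C1C(Nc2cc(F)cc(F)c2)=CC(=O)c2ncccc21` gives 449 nM. Compound 3 `O=C1C=C(Nc2ccccc2)C(=O)c2cnccc21`, built on a different core, gives 439 nM; the difference between the two cores is not broken down here.

Compound 1 and compound 2 are separated by one change, (fluoro in place of hydrogen on an aromatic carbon), and this step gave a 1.8-fold lower number from compound 1 to compound 2 (0.25 log units; within the scatter).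

Compound 4 `O=C1C=C(Nc2ccc(F)cc2)C(=O)c2cnccc21` has not yet been measured. It differs from compound 3 by the same kind of change, (fluoro in place of hydrogen on an aromatic carbon), though here the fluoro sits para to a large group rather than meta to a fluoro group and meta to a large group.

Compound 4 is therefore expected to show about a 1.3-fold lower number from compound 3 to compound 4 (0.10 log units; within the scatter) in this assay, resting on the small step seen from compound 1 to compound 2 a 1.8-fold lower number from compound 1 to compound 2 (0.25 log units; within the scatter). The estimate for compound 4 is 350 nM, with a likely range from 150 nM to 800 nM.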

Compound 4, half-maximal effective concentration: 1230 nM
Compound 4: the middle estimate sits 3.5-fold (0.55 log units) below what was measured; the whole stated range lies below it.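

In this assay, placing a fluoro para to a large group gave a 2.8-fold higher number from compound 3 to compound 4 (0.45 log units; beyond the scatter). For the compounds shown here, the same kind of change therefore did not carry over from one core to the other with the same size or direction: the same change on two cores in this assay, a 1.8-fold lower number (0.25 log units; within the scatter) from compound 1 to compound 2 and a 2.8-fold higher number (0.45 log units; beyond the scatter) from compound 3 to compound 4, 5.0-fold (0.70 log units) apart, beyond the scatter of two such steps What this does not show is whether the core itself sets the difference: the fluoro sits in a different place in the two pairs, and each core offers only one such pair.

As far as these compounds go, it remains open whether a fluoro placed alike on both cores would give matching steps. Also open, from the compounds shown here alone, is whether a chloro or a methoxy group in that same place on the core of compound 3 would shift the number as fluoro does.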